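Methoxymethyl for trifluoromethyl on two cores

This account rests on a few compounds, and the source may have more. Where it says the series, first, only, none or still open, it means among the compounds named here.

Compound 1 `O=C(O)CCCSCCN1C(=O)OC[C@@H]1/C=C/[C@@H](O)Cc1cccc(C(F)(F)F)c1` — in an assay on CHO cells for displacement of a labelled ligand from prostaglandin E2 receptor EP2 subtype (Mus musculus), read by scintillation counting, with a stated time of 60 min (on this read-out higher numbers stand for weaker inhibition and lower numbers for stronger inhibition), compound 1 gives only a limit, > 10000 nM.
Compound 2 `O=C(O)CCCSCCN1C(=O)SC[C@@H]1/C=C/[C@@H](O)Cc1cccc(C(F)(F)F)c1` — in this assay compound 2 gives only a limit, > 10000 nM.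
Compound 3 `COCc1cccc(C[C@H](O)/C=C/[C@H]2COC(=O)N2CCSCCCC(=O)O)c1` — in this assay compound 3 gives only a limit, > 10000 nM.

Compound 2 differs from compound 1 in the core; that difference is not broken down here. Compound 3 differs from compound 1 by methoxymethyl in place of trifluoromethyl on an aromatic carbon. The step that the two limits leave unreadable from compound 1 to compound 3 cannot be read because both values sit at the limit (the limit of > 10000 nM in this assay, at which 3 of the 3 values shown sit).

Compound 4 `COCc1cccc(C[C@H](O)/C=C/[C@H]2CSC(=O)N2CCSCCCC(=O)O)c1`, not yet measured, differs from compound 2 by methoxymethyl in place of trifluoromethyl on an aromatic carbon, the same change on the core of compound 2. With compound 2 known only as a limit and compound 1 and compound 3 both at the same limit, no readable step is expected from the change: a step that the limit leaves unreadable from compound 2 to compound 4 is the expected step. Compound 4 is therefore expected to stay at the limit in this assay, estimated at 20000 nM with a range from 5000 nM to 100000 nM.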

Compound 4, inhibition constant: > 10000 nM
Compound 4 was reported as a limit; the forecaster's own chance of this, stated with the estimate: 85%; the middle value lies beyond the limit too.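

No new step can be read from compound 2 to compound 4, as the methoxymethyl for trifluoromethyl change joins two limits in this assay: the limit of > 10000 nM in this assay, at which 4 of the 4 values shown sit.

The compounds shown leave open whether this change, or the difference between the two cores, alters the read-out at all, as none of them gives a number.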